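The source may report more compounds than this note shows. Statements on the series, on what has been measured and on what is new or still open speak of the compounds shown alone.

Measured in an ADME assay on MRC5 cells (Homo sapiens) for cytotoxicity, read by MTT assay, with a stated time of 72 h; on this read-out lower numbers stand for stronger inhibition and higher numbers for weaker inhibition:
compound 1 `O=C(COc1ccccc1)Nc1nnc(-c2cccc(O)c2O)s1`: 33900 nM
compound 2 `O=C(COc1ccccc1)Nc1nnc(-c2ccc(O)c(O)c2)s1`: 30900 nM

For the measured compounds named here, compound 1 cannot be separated from the only other measured compound: a 1.1-fold lower number from compound 1 to compound 2 (0.04 log units; within the scatter). Compound 3 `CC(=O)Nc1nnc(-c2cccc(O)c2O)s1` keeps the 2,3-dihydroxyphenyl of compound 1 and differs by hydrogen in place of phenoxy on a saturated chain carbon bound to a carbonyl carbon. Going by the values given here, the one measured step lies at another place and gives no size for this change. A modest move to a higher number in this assay is expected, an estimated 1.8-fold higher number from compound 1 to compound 3 (0.25 log units; within the scatter). For compound 3 the expected value is 60000 nM, with an estimated range of 20000 nM to 180000 nM.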

Compound 3, half-maximal inhibitory concentration: 156000 nM
Compound 3: middle estimate off by 2.6-fold (0.41 log units), on the low side; the range from low to high includes it.
By their numbers in this assay, from the lowest: compounds 2 and 1 (each within the scatter of the next); then compound 3.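

Cutting phenoxymethyl back to methyl gives the first step in this series beyond the scatter, a 4.6-fold higher number from compound 1 to compound 3 (0.66 log units; beyond the scatter), in this assay. The place on a saturated chain carbon bound to a carbonyl carbon therefore affects this read-out, which the earlier change of dihydroxyphenyl pattern could not show. No available evidence explains the shift.

Still open, going by these compounds, is how an amine, a carboxylic acid or a longer alkyl chain in place of phenoxy would read at this place. Also open, on these data alone, is whether the same change on the 3,4-dihydroxyphenyl of compound 2 would give a similar step.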